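From Isopropyl to Methoxy on a Sensitive Aromatic Ring

The compounds below may be only part of what the source reports. "The series", "measured", "known", "first", "only" and "open" are said of these compounds alone.

Measured so far in a functional assay on the whole organism for inhibition, with Rattus norvegicus as the target; a higher number here means that more compound is needed for the effect, a lower number that less compound is needed:
- Compound 1 `CC(C)c1ccc(OC(C)(Cc2ccccc2)C(=O)O)cc1`: > 10 mg/kg, a limit of the assay
- Compound 2 `CCc1ccc(CC(C)(Oc2ccc(C(C)C)cc2)C(=O)O)cc1`: 0.1 mg/kg
- Compound 3 `CC(C)c1ccc(CC(C)(Oc2ccc(C(C)C)cc2)C(=O)O)cc1`: 5 mg/kg

Of the two values that are true numbers, compound 3 holds the higher one, 5 mg/kg. The next compound to consider is compound 4 `COc1ccc(CC(C)(Oc2ccc(C(C)C)cc2)C(=O)O)cc1`, which carries methoxy in place of isopropyl on an aromatic carbon, para to a large group (methoxy in place of isopropyl on an aromatic carbon).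

Among the compounds with values here, three measured steps bear on this position. Adding a group there gives an at least 100-fold lower number from compound 1 to compound 2 (2.00 log units; beyond the scatter) with ethyl, but only an at least 2.0-fold lower number from compound 1 to compound 3 (0.30 log units; that floor lies within the scatter) with isopropyl. The clearest guide is a 50-fold higher number from compound 2 to compound 3 (1.70 log units; beyond the scatter), which shows that one extra methyl on this group can matter greatly. Methoxy has not been measured here, so the expectation is uncertain, but removing isopropyl should lead towards lower numbers in this assay, probably without fully reaching compound 2 at 0.1 mg/kg. The expected change is a 7.1-fold lower number from compound 3 to compound 4 (0.85 log units; beyond the scatter). The estimate for compound 4 is 0.7 mg/kg, with an expected range from 0.1 mg/kg to 5 mg/kg.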

Compound 4, dose for half-maximal effect: > 10 mg/kg
Compound 4 was reported as a limit (the forecaster's own chance of this, stated with the estimate: 10%); middle value at least 14-fold (1.15 log units) from the limit.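

Methoxy does not share what ethyl does on this aromatic carbon in this assay: the swap gives an at least 100-fold higher number from compound 2 to compound 4 (2.00 log units; beyond the scatter). Against isopropyl, the change gives an at least 2.0-fold higher number from compound 3 to compound 4 (0.30 log units; that floor lies within the scatter), so replacing isopropyl with methoxy shows no gain, and the true size of this change remains unknown. Compound 4 is reported only as a limit, and the step to it from compound 1, which is also a limit, cannot be read: the limit of > 10 mg/kg in this assay, at which 2 of the 4 values shown sit.

On these data alone, of the four compounds, only compound 2, with ethyl, reaches a low number, and it remains open whether a propyl chain, a chlorine atom or a hydroxyl group on this carbon would do the same. It is also unclear whether the oxygen of methoxy sets compound 4 apart from compound 2, a question that an ethoxy group could help to test.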